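A few compounds are considered here, and "the series" means these few. Any claim that something is new, unique, unknown or untested is made for them only; others in the source may bear on it.

Compound 1 `N#Cc1cc(C(=O)N2CCc3ccccc32)ccc1O`: 2500 nM in an assay on tissue (RPTEC cells) for inhibition of solute carrier family 22 member 12 (Homo sapiens), read by scintillation counting, with stated times of 15 min and 2 h; a higher number here means a weaker inhibitor, a lower number a stronger inhibitor
Compound 2 `COc1cc(C(=O)N2CCc3ccccc32)cc(C#N)c1O`: a limit of > 100000 nM in this assay

Compound 2 sits at the limit of this assay, (the limit of > 100000 nM in this assay, at which 1 of the 2 values shown sits), and so only a range is known for it. Compound 3 `N#Cc1cc(C(=O)N2CCc3ccccc32)cc(I)c1O` differs from it in one place: iodo in place of methoxy on an aromatic carbon. Among the compounds with values here, the only measured step that bears on this position is an at least 40-fold higher number from compound 1 to compound 2 (1.60 log units; beyond the scatter), which shows that the position is sensitive. Since iodo is not methoxy and not hydrogen, the expected step of an at least 12-fold lower number from compound 2 to compound 3 (1.09 log units; beyond the scatter) is taken as a return toward compound 1 without reaching it. Compound 3 is therefore estimated at 8000 nM in this assay, in a range from 1500 nM to 60000 nM.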

Compound 3, half-maximal inhibitory concentration: 5300 nM
For compound 3 the middle estimate is 1.5-fold (0.18 log units) above the measured one; measured number inside the range.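

Iodo in place of methoxy on this aromatic carbon gives an at least 18-fold lower number from compound 2 to compound 3 (1.27 log units; beyond the scatter) in this assay, so the position does not reject every group larger than hydrogen. Measured against hydrogen, iodo gives only a 2.1-fold higher number from compound 1 to compound 3 (0.33 log units; beyond the scatter), a modest step though beyond the scatter. The step from methoxy has an open end, as compound 2 is known only as a limit: the limit of > 100000 nM in this assay, at which 1 of the 3 values shown sits.

With only hydrogen, methoxy and iodo shown here, the compounds leave open how a fluoro, a methyl or an amine would fare on this carbon. They also leave open what separates iodo from methoxy in this assay.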